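Swapping an Aromatic Ring for a Saturated One

A few compounds are considered here, and "the series" means these few. Any claim that something is new, unique, unknown or untested is made for them only; others in the source may bear on it.

Compound 1, `O=c1cc(NC2CC2)cc(-c2ccccc2)o1`, gives only a limit of > 30 uM in a functional assay on KBVIN cells (Homo sapiens) for cytotoxicity, read by MTT assay, with a stated time of 72 h; on this read-out lower numbers stand for an effect already at smaller amounts and higher numbers for an effect only at larger amounts of compound.
Compound 2, `O=c1cc(Nc2ccccc2)cc(-c2ccccc2)o1`, gives 0.15 uM in this assay.
Compound 3, `Cc1ccc(Nc2cc(-c3ccccc3)oc(=O)c2)cc1`, gives 0.059 uM in this assay.

Of the two numbers measured, compound 3 stands lowest; its nearest neighbour is compound 2, with a 2.5-fold lower number from compound 2 to compound 3 (0.41 log units; beyond the scatter). The unmeasured compound 4, `O=c1cc(NC2CCCCC2)cc(-c2ccccc2)o1`, differs from compound 3 by cyclohexyl in place of 4-methylphenyl on a nitrogen on an aromatic ring. The measured steps that bear on this run in the opposite direction: an at least 200-fold lower number from compound 1 to compound 2 (2.30 log units; beyond the scatter) and an at least 500-fold lower number from compound 1 to compound 3 (2.70 log units; beyond the scatter), where a non-aromatic ring on the nitrogen gave way to an aromatic one, and the non-aromatic starting point sat at the limit of > 30 uM in this assay, at which 1 of the 3 values shown sits. Cyclohexyl is not cyclopropyl, so the comparison is indirect, yet the only non-aromatic ring in this place so far came with a limit rather than a number. For compound 4 a large rise in number is therefore expected, a 340-fold higher number from compound 3 to compound 4 (2.53 log units; beyond the scatter), and the assay may again report only a limit. The estimate for compound 4 is 20 uM, within a range from 3 uM to 100 uM.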

Compound 4, concentration for half-maximal effect: 9.15 uM
Beside the measured number, compound 4's estimate is 2.2-fold (0.34 log units) above it; measured number inside the range.
By their numbers in this assay, from the lowest: compound 3; then compound 2; then compound 4. At a limit, above all of these: compound 1.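

Keeping a six-membered ring of carbon only on the nitrogen does not keep the low numbers: in this assay there is a 160-fold higher number from compound 3 to compound 4 (2.19 log units; beyond the scatter), and a 61-fold higher number from compound 2 to compound 4 (1.79 log units; beyond the scatter), so among the compounds shown, a ring of this size is not enough without being aromatic. Non-aromatic rings are not all alike in this place, however, as there is an at least 3.2-fold lower number from compound 1 to compound 4 (0.51 log units; beyond the scatter). The value of compound 1 is a limit and not a number: the limit of > 30 uM in this assay, at which 1 of the 4 values shown sits.

The compounds shown leave open how a pyridyl ring, aromatic but with a nitrogen in the ring, would compare with phenyl in this place. They also leave open whether an open chain such as hexyl would give a number closer to that of the cyclohexyl compound 4 or to those of the aromatic compounds.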